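Adding a second fluorine where only limits are known

A few compounds are considered here, and "the series" means these few. Any claim that something is new, unique, unknown or untested is made for them only; others in the source may bear on it.

In an ADME assay on HEK293 cells (Homo sapiens) for cytotoxicity, with a stated time of 72 h (on this read-out lower numbers stand for an effect already at smaller amounts and higher numbers for an effect only at larger amounts of compound), compound 1 `C=C[C@@](C)(/C=C/c1ccc(OCc2ccccc2)cc1)CCC=C(C)C` gives > 36600 nM, which is a limit and not a number. Compound 2 `C=C[C@@](C)(/C=C/c1ccc(OS(=O)(=O)C(F)(F)F)cc1)CCC=C(C)C` gives > 36600 nM, again only a limit. Compound 3 `C=C[C@@](C)(/C=C/c1ccc(Nc2ccc(F)cc2)cc1)CCC=C(C)C` gives > 36600 nM, also only a limit. Compound 3 therefore has no exact value and stands with the other two, on (the limit of > 36600 nM in this assay, at which 3 of the 3 values shown sit).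

Compound 4 `C=C[C@@](C)(/C=C/c1ccc(Nc2cc(F)cc(F)c2)cc1)CCC=C(C)C` differs from compound 3 in one place: 3,5-difluorophenyl in place of 4-fluorophenyl on a nitrogen on an aromatic ring. In short, 3,5-difluorophenyl stands in place of 4-fluorophenyl on a nitrogen on an aromatic ring.

Two measured steps involve the (4-fluorophenyl)amino group, and neither has a size that can be read. For the measured compounds named here, the first is a step that the two limits leave unreadable from compound 1 to compound 3. The second is a step that the two limits leave unreadable from compound 2 to compound 3. Neither step changes the fluorine count on that ring, so the data offer no direction for this change. The expectation in this assay is therefore a step that the limit leaves unreadable from compound 3 to compound 4, with no shift beyond the usual scatter expected in either direction. The most likely report is once more only a limit. For compound 4 the estimated value is 40000 nM, with an expected range from 25000 nM to 70000 nM.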

Compound 4, half-maximal effective concentration: > 36600 nM
Compound 4 ended at the assay's limit (the forecaster's own chance of this, stated with the estimate: 90%); the middle value lies beyond the limit too.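

In this assay compound 4 gives > 36600 nM, which is a limit and not a number. The steps joining compound 4 to compound 1, compound 2 and compound 3 therefore cannot be read, and all four compounds stand together: the limit of > 36600 nM in this assay, at which 4 of the 4 values shown sit. The compounds shown leave open at what concentration any of them would affect these cells, and whether the second fluorine changes that concentration.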